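Nitro to Methoxycarbonyl on the Fused Ring of Compound 2

The source may report more compounds than this note shows. Statements on the series, on what has been measured and on what is new or still open speak of the compounds shown alone.

Measured compounds:
compound 1, `Nc1ccccc1NC(=O)c1ccc(CSC(=S)N2CCc3ccccc32)cc1`, in a functional assay on A-375 cells (Homo sapiens) for antiproliferative activity, read by CCK-8 assay, with a stated time of 72 h, tested at 2 uM (on this read-out lower numbers stand for a weaker effect and higher numbers for a stronger effect at the one concentration tested), gives 25.7%
compound 2, `Nc1ccccc1NC(=O)c1ccc(CSC(=S)N2CCc3cc([N+](=O)[O-])ccc32)cc1`, in this assay gives 16.9%

Among the measured compounds shown here, compound 2 stands at the lowest of the two numbers measured so far, and its only neighbour, compound 1, sits close by: a number 8.8 percentage points lower from compound 1 to compound 2 (within the scatter). The two values therefore cannot be told apart on this read-out.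

Compound 3, `COC(=O)c1ccc2c(c1)CCN2C(=S)SCc1ccc(C(=O)Nc2ccccc2N)cc1`, has not yet been measured. It differs from compound 2 in a single place: methoxycarbonyl in place of nitro on an aromatic carbon.

For the measured compounds named here, only one measured step exists, the one from compound 1 to compound 2, which placed a nitro group where a hydrogen had been and stayed within the scatter. Going by the values given here, no measured step exchanges a nitro group for a methoxycarbonyl group, so nothing in the numbers points to a shift in either direction. For that reason compound 3 is expected to give a number close to compound 2, with a step of a number 3.1 percentage points higher from compound 2 to compound 3 (within the scatter) that stays within the scatter. Compound 3 is estimated at 20%, in a range from 8% to 34%.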

Compound 3, a percentage reported as inhibition, at one concentration (the size of the read-out at that concentration, not a potency): 37.5%
Estimate against measurement, compound 3: 17.5 percentage points below, and the stated range ends below it.
By their numbers in this assay, from the lowest: compounds 2 and 1 (each within the scatter of the next); then compound 3.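

At this aromatic carbon of the shared core, exchanging nitro for methoxycarbonyl in this assay gives a number 20.6 percentage points higher from compound 2 to compound 3 (beyond the scatter), so the position does respond to what it carries, which the earlier pair could not show. Methoxycarbonyl also separates from hydrogen at this carbon, with a number 11.8 percentage points higher from compound 1 to compound 3 (beyond the scatter), whereas nitro in place of hydrogen gave only a number 8.8 percentage points lower from compound 1 to compound 2 (within the scatter), a step that could not be told apart from repeated measurement. The result therefore depends on the group entering and not merely on the hydrogen being replaced, although with three compounds this holds for nitro and methoxycarbonyl alone, and nothing available accounts for the difference between them.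

The compounds shown leave open whether a carboxylic acid, a primary amide or an ethyl ester at this same aromatic carbon would keep the higher number of compound 3, or whether that number belongs to methoxycarbonyl alone. They also leave open how an amine at this carbon would compare, and whether the order seen at the one tested concentration would hold at other concentrations.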